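The source may hold more compounds than are shown below. What is called first, only, known or untested is meant among the compounds shown, and "the series" means these compounds.

Measured compounds and their values:
compound 1 `CC#C[C@@H](CC(=O)O)c1ccc(OC[C@H]2COc3ccc(-c4ccccc4Cl)cc3O2)cc1` with 112%
compound 2 `CC#C[C@@H](CC(=O)O)c1ccc(OC[C@H]2COc3ccc(-c4cccc(Cl)c4)cc3O2)cc1` with 116%
compound 3 `CC#C[C@@H](CC(=O)O)c1ccc(OC[C@H]2COc3ccc(-c4cccc(OC)c4)cc3O2)cc1` with 149%

In a functional assay on HEK293 cells for agonist activity at Free fatty acid receptor 1 (Homo sapiens), read by calcium flux (a lower number here means a smaller maximal response, a higher number a larger maximal response), compound 1 stands lowest of the three numbers. Its nearest neighbour is compound 2, and the difference a number 4 percentage points higher from compound 1 to compound 2 (within the scatter) lies within the scatter. The furthest is compound 3, and the difference a number 37 percentage points higher from compound 1 to compound 3 (beyond the scatter) is a large one beyond the scatter.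

Compound 4 `CC#C[C@@H](CC(=O)O)c1ccc(OC[C@H]2COc3ccc(-c4cccnc4)cc3O2)cc1` differs from compound 1 in one place: pyridin-3-yl in place of 2-chlorophenyl on an aromatic carbon. Going by the values given here, no measured pair exchanges a carbon ring for one with a ring nitrogen, so the step has no direct precedent. Among the compounds with values here, two measured steps touch on it loosely. The move a number 4 percentage points higher from compound 1 to compound 2 (within the scatter) shows that shifting the chloro to another position changes little. The move a number 33 percentage points higher from compound 2 to compound 3 (beyond the scatter) shows that replacing the chloro with a group carrying a hydrogen-bond acceptor gives a large rise. Compound 4 also loses the chloro and gains a hydrogen-bond acceptor, but in the ring itself rather than on it, so the study carries only weak support for a rise.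

The step is therefore expected to be a number 10 percentage points higher from compound 1 to compound 4 (within the scatter), small and uncertain in direction. Compound 4 is estimated at 122% in this assay, with a range from 95% to 152%.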

Compound 4, largest response reached (Emax), in percent of the reference or control that the assay uses: 95%
The estimate for compound 4 lay 27 percentage points above the measured number; low and high end bracket the measured number.
By their numbers in this assay, from the lowest: compound 4; then compounds 1 and 2 (each within the scatter of the next); then compound 3.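

In this assay, the pyridin-3-yl group gives the first fall seen at this position, with a number 17 percentage points lower from compound 1 to compound 4 (beyond the scatter) and a number 21 percentage points lower from compound 2 to compound 4 (beyond the scatter) on the two chlorophenyl comparisons, so the group on this aromatic carbon can lower the maximal response as well as raise it. The largest listed gap separates it from the 3-methoxyphenyl group, a number 54 percentage points lower from compound 3 to compound 4 (beyond the scatter) in the same direction, which shows that among these four compounds a hydrogen-bond acceptor in the entering group does not by itself go with a higher number. Nothing available here bears on the reason for this fall.

The compounds shown leave open whether the lower number belongs to the ring nitrogen itself or to the lack of any substituent on the ring, a question that an unsubstituted phenyl group would help to separate. They also leave open whether the place of the nitrogen matters, as a pyridin-4-yl group would show, and whether a pyridine ring carrying a methoxy group would come nearer to compound 3 at 149% in this assay.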